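This account rests on a few compounds, and the source may have more. Where it says the series, first, only, none or still open, it means among the compounds named here.

Measured compounds in an assay on isolated protein for inhibition of glutathione S-transferase P (Homo sapiens), with a stated time of 10 min; on this read-out lower numbers stand for stronger inhibition and higher numbers for weaker inhibition:
- compound 1, `O=C(O)CCC(=O)OCCCCCCSc1ccc([N+](=O)[O-])c2nonc12`: 530 nM
- compound 2, `O=C(CCC(=O)OCCCCCCSc1ccc([N+](=O)[O-])c2nonc12)Nc1ccc(Br)cc1`: 5090 nM
- compound 3, `COc1ccc(NC(=O)CCC(=O)OCCCCCCSc2ccc([N+](=O)[O-])c3nonc23)cc1`: 420 nM

All three share one core and differ only in the group on the carbonyl carbon of the chain end. Compound 3 gives the lowest of the three numbers, but its gap to compound 1 is within the scatter, so the two cannot be set in order; only compound 2 stands clearly apart, with a 12-fold lower number from compound 2 to compound 3 (1.08 log units; beyond the scatter).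

Compound 4, `CN(C)CCNC(=O)CCC(=O)OCCCCCCSc1ccc([N+](=O)[O-])c2nonc12`, is not yet measured. It differs from compound 3 in one place: 2-(dimethylamino)ethyl in place of 4-methoxyphenyl on an amide-type nitrogen. The measured steps bear on this only indirectly. Among the compounds with values here, changing the amide substituent has given both a small effect, a 1.3-fold lower number from compound 1 to compound 3 (0.10 log units; within the scatter), and a clear worsening, a 9.6-fold higher number from compound 1 to compound 2 (0.98 log units; beyond the scatter); no measured pair swaps an aromatic amide for an open-chain one. The direction of the step from compound 3 to compound 4 is therefore not settled by the data, and the expected step is a 1.7-fold higher number from compound 3 to compound 4 (0.22 log units; within the scatter), small and uncertain. On that basis compound 4 is estimated at 700 nM in this assay, with a range from 250 nM to 2500 nM.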

Compound 4, half-maximal inhibitory concentration: 540 nM
For compound 4 the middle estimate is 1.3-fold (0.11 log units) above the measured one; the range from low to high includes it.
By their numbers in this assay, from the lowest: compounds 3, 1 and 4 (each within the scatter of the next); then compound 2.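

Compound 4 shows that the amide nitrogen in this assay does not need an aromatic ring: the open-chain 2-(dimethylamino)ethyl, which has no ring, gives a result that cannot be told apart from the 4-methoxyphenyl amide (step: a 1.3-fold higher number from compound 3 to compound 4 (0.11 log units; within the scatter)) or from the free acid (step: a 1.0-fold higher number from compound 1 to compound 4 (0.01 log units; within the scatter)). Compound 2 now stands apart from a third neighbour, with a 9.4-fold lower number from compound 2 to compound 4 (0.97 log units; beyond the scatter), so forming an amide at the chain end does not by itself raise the number, and among the amides shown only the 4-bromophenyl one does. No measurement is available that would explain why these groups behave alike or why the 4-bromophenyl amide differs.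

As far as these compounds go, it remains open whether the high number of compound 2 is specific to bromo, which a plain phenyl or a 4-chlorophenyl on the same nitrogen could test. From the compounds shown here alone, it is also open whether the amine in compound 4 matters at all, and a carbon-only butyl chain in place of 2-(dimethylamino)ethyl would separate the amine from the chain.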